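A few compounds are considered here, and "the series" means these few. Any claim that something is new, unique, unknown or untested is made for them only; others in the source may bear on it.

Series notes. For the measured compounds named here, compound 1 `O=C1NCCN1c1ccc(S(=O)(=O)Nc2cccc(Br)c2)cc1` carries a 3-bromophenyl on the sulfonamide nitrogen; in a functional assay on M21 cells (Homo sapiens) for antiproliferative activity, read by sulforhodamine B assay, with a stated time of 48 h (on this read-out higher numbers stand for weaker inhibition and lower numbers for stronger inhibition), compound 1 gives 59 nM, the only full number recorded so far. Compound 2 `CC(C)Cc1ccc(NS(=O)(=O)c2ccc(N3CCNC3=O)cc2)cc1` reaches only a limit of the assay, > 1000 nM. The second value shown is therefore (the limit of > 1000 nM in this assay, at which 1 of the 2 values shown sits). Compound 3 `COc1ccccc1NS(=O)(=O)c1ccc(N2CCNC2=O)cc1` differs from compound 1 by 2-methoxyphenyl in place of 3-bromophenyl on a sulfonamide nitrogen. Going by the values given here, no measured step of this kind exists, so its size is uncertain. Compound 3 is expected to come out weaker, with an expected step of a 5.1-fold higher number from compound 1 to compound 3 (0.71 log units; beyond the scatter). Compound 3 is estimated at 300 nM, within a range of 60 nM to 2000 nM.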

Compound 3, half-maximal inhibitory concentration: 300 nM
Compound 3: the middle estimate sits on the measured number at the digits printed; the measured number falls inside the stated range.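

The sulfonamide nitrogen now has its first readable step: in this assay, 2-methoxyphenyl in place of 3-bromophenyl gives a 5.1-fold higher number from compound 1 to compound 3 (0.71 log units; beyond the scatter). A full number therefore survives this exchange of aryl groups, though the change costs measurable activity. Compound 2 stays a limit of the assay, so steps to it cannot be read: the limit of > 1000 nM in this assay, at which 1 of the 3 values shown sits.

The exchange alters both the substituent and where it sits on the aryl group, and the compounds shown do not separate the two. As far as these compounds go, how a carboxylic acid or an amine on that aryl group would read in this assay remains open.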